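Swapping an end group on a very weak benzimidazole analogue

The source may hold more compounds than are shown below. What is called first, only, known or untested is meant among the compounds shown, and "the series" means these compounds.

Three related compounds have been tested in a functional assay on A2780 cells (Homo sapiens) for inhibition, read by sulforhodamine B assay; on this read-out higher numbers stand for weaker inhibition of growth and lower numbers for stronger inhibition of growth. Compound 1 `Cc1ccc2[nH]c(-c3ccc(-c4ccc(-c5ccc(N(C)C)cc5)cc4)cc3)nc2c1` gives 2210 nM. Compound 2 `Cc1ccc2[nH]c(-c3ccc(-c4ccc(-c5cccc(Cl)c5)cc4)cc3)nc2c1` carries 3-chlorophenyl in place of 4-(dimethylamino)phenyl on an aromatic carbon and gives 2800 nM; the step of a 1.3-fold higher number from compound 1 to compound 2 (0.10 log units; within the scatter) is small enough to count as no real difference. Compound 3 `CN(C)c1ccc(-c2ccc(-c3ccc(-c4nc5ccccc5[nH]4)cc3)cc2)cc1` differs from compound 1 in the core, namely (hydrogen in place of methyl on an aromatic carbon). Compound 3 gives 100000 nM, the weakest result of the three; the step of a 45-fold higher number from compound 1 to compound 3 (1.66 log units; beyond the scatter) is large and well beyond the scatter.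

Compound 4 `Clc1cccc(-c2ccc(-c3ccc(-c4nc5ccccc5[nH]4)cc3)cc2)c1` has not yet been measured. It differs from compound 3 by 3-chlorophenyl in place of 4-(dimethylamino)phenyl on an aromatic carbon. This is the same change that turns compound 1 into compound 2, and among these compounds it occurs twice; the surroundings of the altered site are described identically in both pairs, so the change is the same rather than merely the same kind.

Because the measured example of this change, a 1.3-fold higher number from compound 1 to compound 2 (0.10 log units; within the scatter), stayed within the scatter, the expectation for compound 4 is a step of no change at the digits printed from compound 3 to compound 4 (within the scatter) in this assay, with the uncertainty that a single prior example carries. On that basis compound 4 is estimated at 100000 nM in this assay, with a likely range from 40000 nM to 250000 nM.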

Compound 4, concentration for 50% growth inhibition: 31100 nM
Compound 4: middle estimate off by 3.2-fold (0.51 log units), on the high side; measured number below the stated range.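

In this assay, replacing 4-(dimethylamino)phenyl with 3-chlorophenyl did not have the same outcome on both cores. On the core without the methyl, the change gave a real shift (a 3.2-fold lower number from compound 3 to compound 4 (0.51 log units; beyond the scatter)), and the comparison with the core carrying the methyl shows that the two results differ: (the same change on two cores in this assay, a 1.3-fold higher number (0.10 log units; within the scatter) from compound 1 to compound 2 and a 3.2-fold lower number (0.51 log units; beyond the scatter) from compound 3 to compound 4, 4.1-fold (0.61 log units) apart, beyond the scatter of two such steps). Seen from the other direction, losing the methyl raised the number with the 3-chlorophenyl end group as well (an 11-fold higher number from compound 2 to compound 4 (1.05 log units; beyond the scatter)), so the direction held across both end groups, but the size did not: (the same change on two cores in this assay, a 45-fold higher number (1.66 log units; beyond the scatter) from compound 1 to compound 3 and an 11-fold higher number (1.05 log units; beyond the scatter) from compound 2 to compound 4, 4.1-fold (0.61 log units) apart, beyond the scatter of two such steps). This shows that, within these four compounds, the result of the end-group swap cannot simply be carried from one core to the other, although a single pair on each core does not show why or whether the same would hold for other end groups.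

The compounds shown leave open whether an end group such as a morpholine or a carboxylic acid would also behave differently on the two cores. They also leave open whether an ethyl group or a chlorine in place of the methyl would give a core that behaves like the methyl-bearing one.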